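Hexyl Hydantoin: Turning the Exocyclic Double Bond from E to Z

The compounds below may be only part of what the source reports. "The series", "measured", "known", "first", "only" and "open" are said of these compounds alone.

Of the compounds shown here, two sharing one core have been measured so far. Compound 1 `O=C1NC(=O)N(Cc2ccccc2)/C1=C\c1ccccc1` was tested in a functional assay on A549 cells (Homo sapiens) for antiproliferative activity, read by trypan blue exclusion, with a stated time of 72 h, tested at 20 uM (a higher number here means more inhibition at the concentration tested (going by the name of the read-out), a lower number less inhibition), where compound 1 gives 42%. Compound 2 `CCCCCCN1C(=O)NC(=O)/C1=C\c1ccccc1` carries a hexyl chain in place of the benzyl group, and in this assay compound 2 gives 14%. Among the two numbers, compound 2 stands at the lowest, with compound 1 the nearest at a higher number, a gap beyond the usual scatter.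

The next compound, compound 3 `CCCCCCN1C(=O)NC(=O)/C1=C/c1ccccc1`, differs from compound 2 only in the drawn geometry: the two compounds have the same atoms and bonds and differ only in configuration as drawn: 1 of 1 stereo elements differ; a double bond is drawn E in compound 2 and Z in compound 3. Going by the values given here, no measured pair in this set separates E from Z, so there is nothing to show how large such a step is in this assay or in which direction it runs.

Given that, compound 3 is expected to land close to compound 2, with a step from compound 2 to compound 3 of a number 4 percentage points higher from compound 2 to compound 3 (within the scatter), which the account does not take to be beyond the scatter. Compound 3 is therefore estimated to give 18% in this assay, in a range from 5% to 40%.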

Compound 3, a percentage reported as inhibition, at one concentration (the size of the read-out at that concentration, not a potency): 0%
For compound 3 the middle estimate is 18 percentage points above the measured one, outside the stated range (below it).
By their numbers in this assay, from the lowest: compound 3; then compound 2; then compound 1.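

In this assay, going by these compounds alone, the geometry of the exocyclic double bond, which no earlier pair could speak to, proves to carry a step of its own: there is a number 14 percentage points lower from compound 2 to compound 3 (beyond the scatter) and the Z form, compound 3, gives 0% as the lowest number of the three. Against the benzyl compound, the change described as pentyl in place of phenyl on a saturated chain carbon bound to an amide-type nitrogen in a ring comes with a number 42 percentage points lower from compound 1 to compound 3 (beyond the scatter) and this wider step also includes the change in geometry, so it does not measure the chain alone. The step from compound 2 to compound 3 can be assigned to the configuration as drawn because nothing else separates the pair: the fact that compounds 2 and 3 differ only in the configuration as drawn.

The compounds shown leave open whether the Z geometry would lower the number in the same way with the benzyl group in place of the hexyl chain. They also leave open how a longer chain, or a hexyl chain ending in an amine or a carboxylic acid, would read in either geometry at this single concentration.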